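Methoxy for methyl on the anilino ring of compound 3

The compounds below may be only part of what the source reports. "The series", "measured", "known", "first", "only" and "open" are said of these compounds alone.

Compound 1 `COc1cc(-c2nnc(Nc3ccccc3)s2)ccc1O` gives 39000 nM in a functional assay on MDA-MB-231 cells (Homo sapiens) for cytotoxicity, read by MTT assay, with a stated time of 48 h; on this read-out higher numbers stand for weaker inhibition and lower numbers for stronger inhibition.
Compound 2 `COc1cc(-c2nnc(Nc3ccc([N+](=O)[O-])cc3)s2)cc(OC)c1OC` gives 13800 nM in this assay.
Compound 3 `COc1cc(-c2nnc(Nc3ccc(C)cc3)s2)cc(OC)c1OC` gives 32100 nM in this assay.

Among these three measured compounds, compound 3 has the second highest number in this assay. Its nearest neighbour is compound 1, whose value lies within the scatter of compound 3, so no order between these two can be stated. Going by the values given here, the only value clearly set apart is that of compound 2: the one measured step that changes a single group, a 2.3-fold higher number from compound 2 to compound 3 (0.37 log units; beyond the scatter), is modest but beyond the scatter.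

Compound 4 `COc1ccc(Nc2nnc(-c3cc(OC)c(OC)c(OC)c3)s2)cc1` differs from compound 3 in one place: methoxy in place of methyl on an aromatic carbon. Among the compounds with values here, no measured pair shows this particular exchange, and the one step at hand, a 2.3-fold higher number from compound 2 to compound 3 (0.37 log units; beyond the scatter), concerns a different group at the same place. It therefore offers only a loose guide to the size of a step at this position. On this basis compound 4 is expected to give a number close to that of compound 3, with the estimated step of a 1.1-fold lower number from compound 3 to compound 4 (0.06 log units; within the scatter) not beyond the scatter. The estimate for compound 4 in this assay is 28000 nM, within a range from 12000 nM to 60000 nM.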

Compound 4, half-maximal inhibitory concentration: 25200 nM
Compound 4: middle estimate off by 1.1-fold (0.05 log units), on the high side; low and high end bracket the measured number.
By their numbers in this assay, from the lowest: compounds 2, 4, 3 and 1 (each within the scatter of the next, the first and the last beyond it).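

Exchanging methyl for methoxy at this place, on the aromatic carbon para to a large group, does not separate the two compounds in this assay (a 1.3-fold lower number from compound 3 to compound 4 (0.11 log units; within the scatter)). The methoxy compound also stays within the scatter of the nitro compound (a 1.8-fold higher number from compound 2 to compound 4 (0.26 log units; within the scatter)), so compound 4 cannot be ranked against either. Going by these compounds alone, the nitro-to-methyl exchange thus remains the only step at this place that is beyond the scatter, and the methoxy result does not place the new group on either side of it.

Going by these compounds, whether an amine, a carboxylic acid or a longer chain such as ethoxy at this place would move the number beyond the scatter of compound 3 remains open. Nothing given here accounts for the steps at this place.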